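This account rests on a few compounds, and the source may have more. Where it says the series, first, only, none or still open, it means among the compounds named here.

Of the compounds shown here, three built on one shared core have been tested in a functional assay for inhibition, with Rattus norvegicus as the target (on this read-out higher numbers stand for weaker inhibition and lower numbers for stronger inhibition), and they differ only in the aromatic ring on one nitrogen. Compound 1 `CC(/N=c1\c(O)c(O)\c1=N/c1cccnc1)C(C)(C)C`, with a pyridin-3-yl ring, gives 1950 nM. Compound 2 `CC(/N=c1\c(O)c(O)\c1=N/c1ccccc1)C(C)(C)C`, with a phenyl ring, gives 5400 nM, the higher of the two actual numbers, so it is the weaker inhibitor of this pair. Compound 3 `CC(/N=c1\c(O)c(O)\c1=N/c1ccc(C(F)(F)F)cc1)C(C)(C)C` reaches only a limit of the assay, > 30000 nM.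

The open question is compound 4 `CC(/N=c1\c(O)c(O)\c1=N/c1ccccc1C#N)C(C)(C)C`, whose difference from compound 2 is cyano in place of hydrogen on an aromatic carbon, ortho to a large group.

Two measured steps offer guidance. The step of a 2.8-fold higher number from compound 1 to compound 2 (0.44 log units; beyond the scatter) is modest, but it changes the ring itself and adds no group to it. The step of an at least 5.5-fold higher number from compound 2 to compound 3 (0.74 log units; beyond the scatter) is the closer parallel, since a group replaces hydrogen on an aromatic carbon, and inhibition weakens. That group is trifluoromethyl rather than cyano, however, so this single example is only a loose guide. A modest move towards a higher number is therefore expected in this assay, smaller than the loss seen with compound 3. The expected change is a 2.0-fold higher number from compound 2 to compound 4 (0.31 log units; beyond the scatter). For compound 4 the estimate is 11000 nM, with an expected range from 3000 nM to 30000 nM.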

Compound 4, half-maximal inhibitory concentration: > 30000 nM
Compound 4: only a limit was reported (the forecaster's own chance of this, stated with the estimate: 25%); middle value at least 2.7-fold (0.43 log units) away from the limit.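

In this assay, cyano in place of hydrogen on an aromatic carbon, ortho to a large group, clearly weakens inhibition, giving an at least 5.5-fold higher number from compound 2 to compound 4 (0.74 log units; beyond the scatter). Compound 4 reaches only a limit of the assay, > 30000 nM, so this step gives a minimum size for the loss and not its true size. Before this result, trifluoromethyl on compound 3 was the only group shown replacing a hydrogen on the aromatic ring, whereas two different groups now weaken inhibition relative to compound 2, though neither loss can be sized and the two cannot be set against each other from these values: the limit of > 30000 nM in this assay, at which 2 of the 4 values shown sit.

What the compounds shown leave open is whether the loss belongs to cyano itself or would follow any group at this place, a question that a fluorine atom, a methyl group or an amine in the same spot could help to settle. For the compounds shown here, they also leave open how cyano would behave elsewhere on the phenyl ring, or on the pyridin-3-yl ring of compound 1, the ring that gives the lowest actual number so far.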